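Urea activators: swapping a pyrazole for a pyridine

The source may report more compounds than this note shows. Statements on the series, on what has been measured and on what is new or still open speak of the compounds shown alone.

Measured so far:
compound 1, `CCOC(=O)c1ccc(N(C)C(=O)NCc2ccncc2)cc1`: > 100000 nM
compound 2, `O=C(NCc1cn[nH]c1)Nc1ccc(S(=O)(=O)c2ccccc2)cc1`: 28 nM

Two ureas have been tested in an assay on isolated protein for activation of Nicotinamide phosphoribosyltransferase (Homo sapiens); on this read-out lower numbers stand for an effect already at smaller amounts and higher numbers for an effect only at larger amounts of compound. Compound 1, `CCOC(=O)c1ccc(N(C)C(=O)NCc2ccncc2)cc1`, gives only a limit in this assay, > 100000 nM, and not a number. Among the compounds with values here, compound 2, `O=C(NCc1cn[nH]c1)Nc1ccc(S(=O)(=O)c2ccccc2)cc1`, is the one compound with a measured value, 28 nM, so it stands as the sole fixed point in this assay. Compound 1 contributes only the limit (the limit of > 100000 nM in this assay, at which 1 of the 2 values shown sits).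

Compound 3, `O=C(NCc1ccncc1)Nc1ccc(S(=O)(=O)c2ccccc2)cc1`, is still to be measured. It differs from compound 2 in one place: pyridin-4-yl in place of 1H-pyrazol-4-yl on a saturated chain carbon bound to an amide-type nitrogen. Within the data shown here, no step between measured compounds matches this change, so there is no measured precedent to lean on. A change of this size, on the saturated chain carbon bound to the amide-type nitrogen, is expected to shift activity only moderately, if at all, and the direction is uncertain; a mild weakening is taken as the more likely outcome, giving an expected step of a 2.1-fold higher number from compound 2 to compound 3 (0.33 log units; beyond the scatter).

Compound 3 is therefore estimated at 60 nM in this assay, with a range from 15 nM to 300 nM.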

Compound 3, half-maximal effective concentration: 85 nM
Compound 3: the middle estimate sits 1.4-fold (0.15 log units) below what was measured; measured number inside the range.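

In this assay, within the data shown here, the change from 1H-pyrazol-4-yl to pyridin-4-yl gives the first measured step at this position, on a saturated chain carbon bound to an amide-type nitrogen: a 3.0-fold higher number from compound 2 to compound 3 (0.48 log units; beyond the scatter). The step is modest, and compound 3 still gives 85 nM, so at this position activity at this level does not depend on the five-membered ring or on the hydrogen-bond donor that the 1H-pyrazol-4-yl group carries and the pyridin-4-yl group lacks. Nothing measured here gives a reason for the size or direction of this step.

Going by these compounds, with only these two rings compared, it remains open whether the ring nitrogen is needed at all, as a plain phenyl ring would show, and whether its placement matters, as pyridin-3-yl would show. Compound 1 gives only a limit, > 100000 nM, and it differs from compound 3 in more than one place, so it cannot show which of its differences accounts for that result.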